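The source may hold more compounds than are shown below. What is called first, only, known or untested is meant among the compounds shown, and "the series" means these compounds.

Measured so far in a functional assay on DU-145 cells (Homo sapiens) for antiproliferative activity, read by MTT assay, with a stated time of 48 h; on this read-out higher numbers stand for weaker inhibition and lower numbers for stronger inhibition:
Compound 1 `C/C(=C\CC/C(C)=C/CC[C@@H]1[C@@]2(C)CCC(=O)C(C)(C)[C@H]2CC[C@@]1(C)O)CC/C=C(\C)C(=O)OCc1cn(-c2ccccc2C(F)(F)F)nn1`: > 150000 nM, a limit
Compound 2 `C/C(=C\CC/C(C)=C/CC[C@@H]1[C@@]2(C)CCC(=O)C(C)(C)[C@H]2CC[C@@]1(C)O)CC/C=C(\C)C(=O)OCc1cn(-c2cccc(C)c2)nn1`: 137000 nM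
Compound 3 `C/C(=C\CC/C(C)=C/CC[C@@H]1[C@@]2(C)CCC(=O)C(C)(C)[C@H]2CC[C@@]1(C)O)CC/C=C(\C)C(=O)OCc1cn(-c2ccc(Br)cc2)nn1`: > 150000 nM, a limit

Compound 3 stands at the limit of > 150000 nM in this assay, at which 2 of the 3 values shown sit, so it has no true number. Compound 4 `C/C(=C\CC/C(C)=C/CC[C@@H]1[C@@]2(C)CCC(=O)C(C)(C)[C@H]2CC[C@@]1(C)O)CC/C=C(\C)C(=O)OCc1cn(-c2ccccc2)nn1` has hydrogen in place of bromo on an aromatic carbon, para to a large group (hydrogen in place of bromo on an aromatic carbon). The closest evidence comes from swapping the group on the aromatic nitrogen: an at least 1.0-fold lower number from compound 1 to compound 2 (0.03 log units; that floor lies within the scatter), and an at least 1.0-fold higher number from compound 2 to compound 3 (0.03 log units; that floor lies within the scatter). Beyond these, a step that the two limits leave unreadable from compound 1 to compound 3. Within the data shown here, compound 2 gives the only true number, 137000 nM. No change beyond the scatter is therefore expected in this assay, and the expected size is an at least 1.1-fold lower number from compound 3 to compound 4 (0.06 log units; that floor lies within the scatter). Compound 4 is estimated at 130000 nM, with an expected range from 70000 nM to 150000 nM, and it may be reported only as a limit.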

Compound 4, half-maximal inhibitory concentration: 95500 nM
Compound 4: middle estimate off by 1.4-fold (0.13 log units), on the high side; low and high end bracket the measured number.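

Removing the substituent from the phenyl group gives a second true number in this assay: the result is a 1.4-fold lower number from compound 2 to compound 4 (0.16 log units; within the scatter), so methyl and hydrogen cannot be told apart here. Against the two compounds held at a limit, the result is an at least 1.5-fold lower number from compound 3 to compound 4 (0.19 log units; that floor lies within the scatter) and an at least 1.5-fold lower number from compound 1 to compound 4 (0.19 log units; that floor lies within the scatter); each is only a floor, so the true gaps may be larger. That uncertainty comes from a single limit: the limit of > 150000 nM in this assay, at which 2 of the 4 values shown sit.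

As far as these compounds go, it remains open whether an amine or a carboxylic acid on this phenyl group would move the number beyond the scatter.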